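Moving a fluorine around the sulfonyl-bound ring: cytotoxicity outlook

The source may hold more compounds than are shown below. What is called first, only, known or untested is meant among the compounds shown, and "the series" means these compounds.

Compound 1 `CCC1(c2ccccc2OC)CC(S(=O)(=O)c2ccc(F)cc2)=C(c2ccc(/C(N)=N\O)cc2)O1`: 9880 nM
Compound 2 `CC1(c2ccc(-c3cccc(/C(N)=N\O)c3)cc2)CC(S(=O)(=O)c2ccc(F)cc2)=C(c2ccc(/C(N)=N\O)cc2)O1`: 11000 nM
Compound 3 `CC1(Cc2ccccc2)CC(S(=O)(=O)c2ccccc2F)=C(c2ccc(/C(N)=N\O)cc2)O1`: 29100 nM

Of the compounds shown here, three that share one core have been tested in an ADME assay on J774.A1 cells (Mus musculus) for cytotoxicity, read by MTT assay, with a stated time of 72 h; on this read-out lower numbers stand for higher toxicity in this test and higher numbers for lower toxicity in this test. Compound 1 gives 9880 nM and compound 2 gives 11000 nM; these two values sit within the scatter of each other, so no order between them can be read. Compound 3 gives 29100 nM, the highest number of the three, and its gap to each of the other two compounds lies beyond the scatter, so compound 3 is the least toxic of the three in this assay.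

Compound 4 `CC1(Cc2ccccc2)CC(S(=O)(=O)c2cccc(F)c2)=C(c2ccc(/C(N)=N\O)cc2)O1` has not yet been measured. It is built from the same atoms as compound 3, joined differently: 3-fluorophenyl in place of 2-fluorophenyl on a sulfonyl sulfur

Among the measured compounds shown here, no pair of measured compounds differs by this kind of change, so there is nothing in the numbers that tells how far it moves the read-out. On that basis the step from compound 3 to compound 4 is expected to be small, a 1.2-fold lower number from compound 3 to compound 4 (0.07 log units; within the scatter), and to stay within the scatter. Compound 4 is therefore estimated to give 25000 nM in this assay, with a plausible range from 10000 nM to 60000 nM.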

Compound 4, half-maximal cytotoxic concentration: 28300 nM
Compound 4: the middle estimate sits 1.1-fold (0.05 log units) below what was measured, within the range that was stated.
By their numbers in this assay, from the lowest: compounds 1 and 2 (each within the scatter of the next); then compounds 4 and 3 (each within the scatter of the next).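

Among the compounds shown here, this pair gives the first direct reading of a single change in this assay, since no two earlier compounds differed in only one place. With 3-fluorophenyl in place of 2-fluorophenyl on a sulfonyl sulfur, the step is a 1.0-fold lower number from compound 3 to compound 4 (0.01 log units; within the scatter), so moving the fluorine within this group leaves no difference that can be told from the usual scatter of repeated measurements, and neither compound can be called the less toxic of the two. No measurement is available that would account for this result.

For the compounds shown here, this single pair covers only two fluorophenyl groups, attached to one version of the shared core, so it cannot show whether the same swap would read the same way if another part of the molecule were changed. It also leaves open what would happen to the number in this cell test if an amine or a carboxylic acid took the place of the fluorine on this ring, or if the ring on the sulfonyl sulfur carried a longer chain.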